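A Dimethoxyphenyl Group Replaces the Phenylethenyl Group

This account rests on a few compounds, and the source may have more. Where it says the series, first, only, none or still open, it means among the compounds named here.

Within the data shown here, in a functional assay on CAKI-1 cells (Homo sapiens) for antiproliferative activity, with a stated time of 48 h (on this read-out higher numbers stand for weaker inhibition of growth and lower numbers for stronger inhibition of growth), compound 2 `Cc1cc(O)c(C2=NN(c3ccc(S(N)(=O)=O)cc3)C(/C=C/c3ccccc3)C2)cc1Cl` gives 15300 nM, the highest of the two numbers measured so far; its nearest neighbour is compound 1 `Cc1cc(O)c(C2=NN(c3ccc(S(N)(=O)=O)cc3)C(c3ccccc3Cl)C2)cc1Cl`, which gives 1780 nM. Compound 3 `COc1ccc(C2CC(c3cc(Cl)c(C)cc3O)=NN2c2ccc(S(N)(=O)=O)cc2)cc1OC` differs from compound 2 in one place: 3,4-dimethoxyphenyl in place of 2-phenylethenyl on a saturated ring carbon. Among the measured compounds shown here, the only measured step at this saturated ring carbon is an 8.6-fold higher number from compound 1 to compound 2 (0.93 log units; beyond the scatter), which weakened growth inhibition. Putting an aromatic ring back in this place is therefore expected to lower the number again, by an estimated 4.4-fold lower number from compound 2 to compound 3 (0.64 log units; beyond the scatter). Compound 3 is expected to give 3500 nM, between 1000 nM and 12000 nM.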

Compound 3, concentration for 50% growth inhibition: 2780 nM
The estimate for compound 3 lay 1.3-fold (0.10 log units) above the measured number, and the stated range covers the measured number.
By their numbers in this assay, from the lowest: compounds 1 and 3 (each within the scatter of the next); then compound 2.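

With a 5.5-fold lower number from compound 2 to compound 3 (0.74 log units; beyond the scatter) the number returns to the level of an aromatic ring on this saturated ring carbon, so the weaker growth inhibition belongs to 2-phenylethenyl and not to every change made here. The step of a 1.6-fold higher number from compound 1 to compound 3 (0.19 log units; within the scatter) shows that 3,4-dimethoxyphenyl and 2-chlorophenyl cannot be told apart at this position, although they differ in their substituents. Nothing available explains either step. Still open, as far as these compounds go, is how this position responds to a non-aromatic group, such as an amine, a carboxylic acid or a longer alkyl chain. Also open, from the compounds shown here alone, is whether a single methoxy group on the phenyl ring would serve as well as two.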